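This account rests on a few compounds, and the source may have more. Where it says the series, first, only, none or still open, it means among the compounds named here.

Series notes. Compound 1 `NCCNc1c(C(=O)NCc2ccc(F)cc2)nc(Br)c2cccnc12` carries a (2-aminoethyl)amino chain on the shared core; in a functional assay on MCF7 cells (Homo sapiens) for cytotoxicity, read by MTT assay, with a stated time of 72 h (a higher number here means a weaker inhibitor, a lower number a stronger inhibitor), compound 1 gives 6000 nM. Compound 2 `N[C@H]1CC[C@H](Nc2c(C(=O)NC3CCCCC3)nc(Br)c3cccnc23)CC1` differs from it at both the amine side and the amide side, and in this assay compound 2 gives 5200 nM. Compound 3 `N[C@H]1CC[C@H](Nc2c(C(=O)NCc3ccccc3)nc(Br)c3cccnc23)CC1` shares the amine side of compound 2 with a different amide, and in this assay compound 3 gives "not determined" (no result reported), so no number is available for it. Of the two numbers available, compound 1 has the higher one; the gap to compound 2 lies within the usual scatter, so the two compounds are not separated by these data.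

Compound 4 `NCCCCCCNc1c(C(=O)NCc2ccc(F)cc2)nc(Br)c2cccnc12` differs from compound 1 only at the chain: 4-aminobutyl in place of amino on a saturated chain carbon, two bonds along the chain from a nitrogen on an aromatic ring. Within the data shown here, no pair of measured compounds shows this change on its own, so it has no direct precedent. The two measured numbers sit close together despite substantial differences elsewhere, which gives no sign that this part of the molecule is a strong lever. A step of a 1.2-fold lower number from compound 1 to compound 4 (0.08 log units; within the scatter) is therefore expected, small and most likely within the scatter, with no preferred direction. On that basis compound 4 is estimated at 5000 nM in this assay, with a range from 2000 nM to 15000 nM.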

Compound 4, half-maximal inhibitory concentration: 2000 nM
Beside the measured number, compound 4's estimate is 2.5-fold (0.40 log units) above it; the measured number falls inside the stated range.
By their numbers in this assay, from the lowest: compound 4; then compounds 2 and 1 (each within the scatter of the next).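

Extending the (2-aminoethyl)amino chain to (6-aminohexyl)amino, with the amide side and the rest of the shared core unchanged, gives a 3.0-fold lower number from compound 1 to compound 4 (0.48 log units; beyond the scatter) in this assay, the first change at this position that can be read on its own. The earlier compounds shown here offered no pair differing in one place, and their two numbers could not show whether this chain affects the result; this step, modest but beyond the scatter, shows that lengthening the chain alone can move the number toward stronger inhibition. No evidence on the reason for the step is at hand.

From the compounds shown here alone, a single step fixes the direction for these two chain lengths only, so whether the number falls steadily through a (4-aminobutyl)amino chain, or keeps falling with a still longer chain such as (8-aminooctyl)amino, stays open. Also open, going by these compounds, is the part played by the terminal amine: a hexyl chain ending in a hydroxyl group or a carboxylic acid, on the same amide side, would separate chain length from the end group.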